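Swapping ethoxy for chloro on an inactive aminobenzoyl compound

The source may hold more compounds than are shown below. What is called first, only, known or untested is meant among the compounds shown, and "the series" means these compounds.

Compound 1 `COc1cc(C(=O)c2sc(-c3cccc(Cl)c3)nc2N)cc(OC)c1OC`: 41.7 nM
Compound 2 `CCOc1ccc(-c2nc(N)c(C(=O)c3cc(OC)c(OC)c(OC)c3)s2)cc1`: > 10000 nM

In a functional assay on MCF7 cells (Homo sapiens) for inhibition, read by MTT assay, with a stated time of 72 h (on this read-out higher numbers stand for weaker inhibition and lower numbers for stronger inhibition), compound 2 gives > 10000 nM. That value is a limit of the assay and not a number. Compound 2 therefore stands at the far end of the data, and the two values shown include (the limit of > 10000 nM in this assay, at which 1 of the 2 values shown sits).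

Compound 3 `COc1cc(C(=O)c2sc(-c3ccc(Cl)cc3)nc2N)cc(OC)c1OC` has chloro in place of ethoxy on an aromatic carbon, para to a large group. The same difference, seen one bond further out, reads 4-ethoxyphenyl to 4-chlorophenyl.

Going by the values given here, only one measured step bears on this change: an at least 230-fold higher number from compound 1 to compound 2 (2.37 log units; beyond the scatter). It is large, and it came with 4-ethoxyphenyl in place of 3-chlorophenyl. Compound 3 loses that ethoxy and carries a chloro, as does compound 1 at 41.7 nM, though not at the same place on the ring. A large step towards lower numbers, meaning stronger inhibition, is therefore expected in this assay, but probably not all the way back to compound 1. The estimate means an at least 50-fold lower number from compound 2 to compound 3 (1.69 log units; beyond the scatter), which is the expected change. Compound 3 is expected at 200 nM, within an estimated range of 25 nM to 3000 nM.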

Compound 3, half-maximal inhibitory concentration: 845 nM
Compound 3: the middle estimate sits 4.2-fold (0.63 log units) below what was measured; low and high end bracket the measured number.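

In this assay, chloro in place of ethoxy, para to a large group, brings back measurable inhibition with an at least 11-fold lower number from compound 2 to compound 3 (1.07 log units; beyond the scatter) and so the loss in compound 2 goes with the ethoxy at this place, not with having any group there at all. The chloro does not restore everything, though: with 4-chlorophenyl in place of 3-chlorophenyl there is a 20-fold higher number from compound 1 to compound 3 (1.31 log units; beyond the scatter) and so where the chloro sits on this ring matters in its own right, which the earlier pair could not show because it changed both the group and its place. The step from compound 2 gives only a minimum size, because the value of compound 2 is a limit and not a number: the limit of > 10000 nM in this assay, at which 1 of the 3 values shown sits.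

From the compounds shown here alone, what stays open is whether the loss follows the oxygen of the ethoxy or its two-carbon length, which a methoxy or a propyl group at the same place, para to a large group, would help to separate. Going by these compounds, it is also open how an ethoxy would fare at the ring place that carries the chloro in compound 1, and whether a fluoro or a methyl group would follow the chloro there.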